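Dropping the fluoro from compound 3

The compounds below may be only part of what the source reports. "The series", "measured", "known", "first", "only" and "open" are said of these compounds alone.

Compound 1, `Cc1ccnc(/C(N)=N/NC(=S)N2CCCC2)c1`, gives 25.9% in a functional assay on HeLa cells (Homo sapiens) for cytotoxicity, read by MTT assay, with a stated time of 72 h, tested at 1 uM; on this read-out higher numbers stand for more inhibition of growth at the one concentration tested and lower numbers for less inhibition of growth.
Compound 2, `N/C(=N\NC(=S)N1CCSCC1)c1ccccn1`, gives 25.1%.
Compound 3, `N/C(=N\NC(=S)N1CCOCC1)c1ccc(F)cn1`, gives 21.4%.

The three measured compounds share one core and differ in the ring on the thiourea and in the substitution of the aromatic ring. Among the three numbers, the value of compound 3 is the lowest shown, though its gap to compound 2 and its wider gap to compound 1 both lie within the scatter, so the three read as one cluster.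

Compound 4, `N/C(=N\NC(=S)N1CCOCC1)c1ccccn1`, is the next step. It differs from compound 3 in one place only: hydrogen in place of fluoro on an aromatic carbon. Going by the values given here, no pair of measured compounds differs by a single change, so no measured step can be carried over. Among the compounds with values here, compound 2, which likewise carries no fluoro on its aromatic ring, gives 25.1%, and nothing among the measured compounds points to a step beyond the scatter.

For compound 4 the expected step is a number 2.6 percentage points higher from compound 3 to compound 4 (within the scatter), none beyond the scatter. Compound 4 is estimated at 24%, in a range from 14% to 34%.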

Compound 4, percent growth inhibition at one concentration: 12.7%
The estimate for compound 4 lay 11.3 percentage points above the measured number; the measured number lies below the stated range.
By their numbers in this assay, from the lowest: compounds 4, 3, 2 and 1 (each within the scatter of the next, the first and the last beyond it).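

In this assay, hydrogen in place of fluoro on this aromatic carbon, two atoms from the ring nitrogen and para to a large group, gives a number 8.7 percentage points lower from compound 3 to compound 4 (within the scatter) and so does not show that the fluoro matters at this position. Going by these compounds alone, the first single change to go beyond the scatter lies on the thiocarbonyl carbon instead, where morpholin-4-yl in place of thiomorpholin-4-yl gives a number 12.4 percentage points lower from compound 2 to compound 4 (beyond the scatter) and the step is modest. Nothing available explains either step.

From the compounds shown here alone, whether chloro, methoxy or an amine on the same aromatic carbon would stand apart from fluoro and hydrogen remains open. So does whether the step between morpholin-4-yl and thiomorpholin-4-yl would hold with fluoro on the aromatic ring, and where piperidin-1-yl would fall on the thiocarbonyl carbon.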